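This account rests on a few compounds, and the source may have more. Where it says the series, first, only, none or still open, it means among the compounds named here.

Measured compounds:
Compound 1 `COc1cc2c(Oc3c(F)cc(NC(=O)NN4C(=O)CSC4c4c(F)cccc4F)cc3F)ccnc2cc1OCCCN1CCCC1`: 230 nM
Compound 2 `COc1cc2c(Oc3c(F)cc(NC(=O)NN4C(=O)CCSC4c4c(F)cccc4F)cc3F)ccnc2cc1OCCCN1CCCC1`: 270 nM
Compound 3 `COc1cc2c(Oc3c(F)cc(NC(=S)NN4C(=O)CSC4c4c(F)cccc4F)cc3F)ccnc2cc1OCCCN1CCCC1`: 410 nM

In a functional assay on HT-29 cells (Homo sapiens) for antiproliferative activity, read by MTT assay, with a stated time of 72 h (a lower number here means a stronger inhibitor, a higher number a weaker inhibitor), compound 1 gives 230 nM, the lowest of the three numbers, while compound 2 gives 270 nM and compound 3 gives 410 nM, both gaps to compound 1 lying within the usual scatter. Compound 4 `COc1cc2c(Oc3c(F)cc(NC(=O)NN4C(=O)CSC4c4c(F)cccc4F)cc3F)ccnc2cc1OCCCN1CCC(N2CCCCC2)CC1` is built from compound 1 by 4-(piperidin-1-yl)piperidin-1-yl in place of pyrrolidin-1-yl on a saturated chain carbon, three bonds along the chain from an oxygen on an aromatic ring. No measured pair in this set differs in that way, so the step cannot be read off from the numbers shown. Compound 4 is therefore expected to stay close to compound 1, with a step of a 1.1-fold higher number from compound 1 to compound 4 (0.04 log units; within the scatter) that is not expected to exceed the scatter in either direction. The estimate for compound 4 in this assay is 250 nM, with a range from 80 nM to 800 nM.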

Compound 4, half-maximal inhibitory concentration: 280 nM
For compound 4 the middle estimate is 1.1-fold (0.05 log units) below the measured one; measured number inside the range.
By their numbers in this assay, from the lowest: compounds 1, 2, 4 and 3 (each within the scatter of the next).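

In this assay, 4-(piperidin-1-yl)piperidin-1-yl in place of pyrrolidin-1-yl gives a 1.2-fold higher number from compound 1 to compound 4 (0.09 log units; within the scatter). At this position on the chain, then, a group of 12 heavy atoms with two six-membered rings reads the same as one of 5 heavy atoms with a single five-membered ring. Nothing available explains why the larger group leaves the number within the scatter.

Open, as far as these compounds go, is whether a morpholine, a piperazine or an open-chain dimethylamine at this place, or a carboxylic acid, would read alike. Also open, from the compounds shown here alone, is whether a longer chain to the oxygen would change the picture.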